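Swapping the Thiocarbonyl Substituent in a Benzamide Series

The source may hold more compounds than are shown below. What is called first, only, known or untested is meant among the compounds shown, and "the series" means these compounds.

The three measured compounds, all read in a functional assay on A-375 cells (Homo sapiens) for antiproliferative activity, read by CCK-8 assay, with a stated time of 72 h, tested at 8 uM; a lower number here means a weaker effect, a higher number a stronger effect of the compound at the concentration tested:
Compound 1, `CN(C(=S)SCc1ccc(C(=O)Nc2ccccc2N)cc1)c1cccnc1`, gives 87.7%.
Compound 2, `Nc1ccccc1NC(=O)c1ccc(CSC(=S)N2CCc3cc(Cl)ccc32)cc1`, gives 82.3%.
Compound 3, `CC1CCCCN1C(=S)SCc1ccc(C(=O)Nc2ccccc2N)cc1`, gives 85.2%.

Compound 3 stands second highest of the three numbers, but its neighbours sit close on either side: the step of a number 2.5 percentage points lower from compound 1 to compound 3 (within the scatter) and the step of a number 2.9 percentage points higher from compound 2 to compound 3 (within the scatter) both fall within the scatter, so the three compounds cannot be told apart on these numbers.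

Compound 4, `CN(Cc1cccnc1)C(=S)SCc1ccc(C(=O)Nc2ccccc2N)cc1`, is not yet measured. It differs from compound 3 in one place: methyl((pyridin-3-yl)methyl)amino in place of 2-methylpiperidin-1-yl on a thiocarbonyl carbon. Within the data shown here, the group that enters resembles the one found in compound 1, with the pyridine ring held one carbon further from the amino nitrogen.

Every measured step bears on this change, since each of them also swaps the group on the thiocarbonyl carbon while the rest of the shared core stays fixed. Those steps were a number 5.4 percentage points lower from compound 1 to compound 2 (within the scatter), a number 2.5 percentage points lower from compound 1 to compound 3 (within the scatter) and a number 2.9 percentage points higher from compound 2 to compound 3 (within the scatter), none of them beyond the scatter. The expected step from compound 3 to compound 4 is therefore a number 0.2 percentage points lower from compound 3 to compound 4 (within the scatter), which is no step beyond the scatter in either direction.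

Compound 4 is estimated to give 85% in this assay, in a range from 76% to 92%.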

Compound 4, a percentage reported as inhibition, at one concentration (the size of the read-out at that concentration, not a potency): 83.8%
Compound 4: middle estimate off by 1.2 percentage points, on the high side, within the range that was stated.
By their numbers in this assay, from the lowest: compounds 2, 4, 3 and 1 (each within the scatter of the next).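

What this adds is a group of a different kind: in this assay, methyl((pyridin-3-yl)methyl)amino brings a six-membered aromatic ring where 2-methylpiperidin-1-yl had a six-membered non-aromatic ring, and the result is small (a number 1.4 percentage points lower from compound 3 to compound 4 (within the scatter)). Compound 4 also allows two further comparisons: placing (pyridin-3-yl)methyl rather than pyridin-3-yl on the amide-type nitrogen gives (a number 3.9 percentage points lower from compound 1 to compound 4 (within the scatter)), while the comparison with the 5-chloro-2,3-dihydro-1H-indol-1-yl group gives (a number 1.5 percentage points higher from compound 2 to compound 4 (within the scatter)), so all four groups on the thiocarbonyl carbon remain indistinguishable at this single concentration. Nothing available explains why these different groups cannot be separated.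

With one concentration and all four compounds within the scatter of one another, any differences in potency remain hidden. Going by these compounds, it also remains open whether a morpholine ring, a carboxylic acid or a longer chain leading to the pyridine ring on the thiocarbonyl carbon would separate from these four compounds in this assay.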